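The source may hold more compounds than are shown below. What is called first, only, known or untested is meant among the compounds shown, and "the series" means these compounds.

Of the compounds shown here, three have been measured in an in vitro functional assay on SH-EP1 cells for agonist activity at Neuronal acetylcholine receptor; alpha4/beta2 (Homo sapiens), read by voltage clamp; on this read-out higher numbers stand for an effect only at larger amounts of compound and lower numbers for an effect already at smaller amounts: compound 1, `CN1C[C@H]2C=C(c3cccnc3)C[C@H](C2)C1`, gives 3500 nM; compound 2, `C1=C(c2cccnc2)C[C@H]2CNC[C@@H]1C2`, gives 100 nM; compound 3, `CC(C)Oc1cncc(C2=CC3CNCC(C2)C3)c1`, gives 1400 nM.

Compound 2 and compound 1 differ in one place only, (methyl in place of hydrogen on an amine nitrogen in a ring). In this assay that single change produced a 35-fold higher number from compound 2 to compound 1 (1.54 log units; beyond the scatter), a large step well beyond the usual scatter. Compound 3 carries the same unsubstituted ring amine as compound 2, yet the difference between the two cores is not broken down here; its value sits between those of compound 2 and compound 1.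

Compound 4, `CC(C)Oc1cncc(C2=CC3CC(C2)CN(C)C3)c1`, has not yet been measured. It differs from compound 3 by methyl in place of hydrogen on an amine nitrogen in a ring, the same change that separates compound 2 from compound 1, at a place described in exactly the same words. Within the data shown here, because a 35-fold higher number from compound 2 to compound 1 (1.54 log units; beyond the scatter) was large, a step of comparable size is expected when this change is applied to compound 3, although only one earlier example supports this. For compound 4 in this assay a value near 40000 nM is estimated, with a likely range from 10000 nM to 160000 nM. This corresponds to an expected 29-fold higher number from compound 3 to compound 4 (1.46 log units; beyond the scatter).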

Compound 4, half-maximal effective concentration: 3500 nM
The estimate for compound 4 lay 11-fold (1.06 log units) above the measured number, and the stated range ends above it.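

In this assay, methyl in place of hydrogen on the amine nitrogen in the ring gave a 2.5-fold higher number from compound 3 to compound 4 (0.40 log units; beyond the scatter), so the number rose on this core too, but the size of the step did not carry over from the earlier pair: the same change on two cores in this assay, a 35-fold higher number (1.54 log units; beyond the scatter) from compound 2 to compound 1 and a 2.5-fold higher number (0.40 log units; beyond the scatter) from compound 3 to compound 4, 14-fold (1.15 log units) apart, beyond the scatter of two such steps

The direction of the change was therefore the same in both pairs of compounds, while a step measured on one core proved a poor guide to the size of the step on the other. Among these compounds, with only two pairs, these results show neither why the two steps differ nor whether the same direction would hold on any further core.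

The compounds shown leave open what an ethyl group or a longer chain would do in place of the methyl on that nitrogen. They also leave open whether an amide at the same nitrogen, where the basic amine is replaced, would fit either pair's trend.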